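Removing a methoxy group from a triazole thioether oxime

The source may hold more compounds than are shown below. What is called first, only, known or untested is meant among the compounds shown, and "the series" means these compounds.

Of the compounds shown here, three of one series have been measured in a functional assay on the whole organism (strain albino) for inhibition, with Rattus norvegicus as the target, read by paw edema, with a stated time of 2 h, at a dose of 0.28 mmol/kg by the oral route; a higher number here means more inhibition at the dose given (going by the name of the read-out), a lower number less inhibition. Compound 1 `C=CCn1c(SCC(=O)c2ccccc2)nnc1-c1ccccc1` gives 58%, compound 2 `COc1ccc(-c2nnc(SC/C(=N/O)c3ccccc3)n2-c2ccccc2)cc1` gives 63%, and compound 3 `CCn1c(SCC(=O)c2ccccc2)nnc1-c1ccc(OC)cc1` gives 60%. Compound 2 holds the highest of the three numbers, yet its distances to compound 3 and to compound 1 both lie within the scatter, so the three cannot be ordered on these data.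

The step under consideration leads from compound 2 to compound 4 `O/N=C(/CSc1nnc(-c2ccccc2)n1-c1ccccc1)c1ccccc1`, which has not been measured in this assay. The change is hydrogen in place of methoxy on an aromatic carbon. Within the data shown here, no pair of measured compounds differing in only one place is available, so the size of this step has to be judged from the spread of the three numbers alone, all of which lie close together regardless of whether the phenyl carries a methoxy or not.

On that basis the step from compound 2 to compound 4 is expected to be a number 4 percentage points lower from compound 2 to compound 4 (within the scatter), no more than the scatter. Compound 4 is therefore estimated at 59%, within a range from 48% to 70%.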

Compound 4, a percentage reported as inhibition, in the whole organism at one dose (the size of the read-out at that dose, not a potency): 63%
The estimate for compound 4 lay 4 percentage points below the measured number; measured number inside the range.
By their numbers in this assay, from the lowest: compounds 1, 3, 2 and 4 (each within the scatter of the next).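

In this assay, among these compounds, this is the first direct reading of this position: hydrogen in place of methoxy gives no change at the digits printed from compound 2 to compound 4 (within the scatter) and so the 4-methoxyphenyl to phenyl change, on an aromatic carbon para to a large group, leaves the number where it stood. For this pair, the methoxy group is therefore not required for the inhibition seen at this one dose. Nothing available bears on why the number holds when the methoxy group leaves.

The compounds shown leave open whether another group at this place, such as an amine, a carboxylic acid or a trifluoromethyl group, would move the number beyond the scatter. They also leave open whether this pair would stay level at other doses or other times.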